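Permeability of a quinoline-free cyclohexyl analogue, estimated before measurement

The compounds below may be only part of what the source reports. "The series", "measured", "known", "first", "only" and "open" are said of these compounds alone.

Compound 1 `Cc1cc(C)cc(Cc2ccc3c(NCCCNCc4ccco4)ccnc3c2)c1` gives 23 10^-6 cm/s in an ADME assay for permeability, using PAMPA, with a stated time of 30 min, at pH 7.4; on this read-out higher numbers stand for higher permeability and lower numbers for lower permeability.
Compound 2 `COc1ccc(F)cc1CNCCCNc1ccnc2cc(Cc3cc(C)cc(C)c3)ccc12` gives 23 10^-6 cm/s in this assay.

Compound 1 stands level with compound 2 at the digits shown. For the measured compounds named here, the one measured step, no change at the digits printed from compound 1 to compound 2 (within the scatter), swaps 5-fluoro-2-methoxyphenyl for furan-2-yl on a saturated chain carbon bound to an amine nitrogen, a change at the far end of the molecule from the one considered here.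

Compound 3 `c1coc(CNCCCNc2ccnc3cc(C4CCCCC4)ccc23)c1` differs from compound 1 by cyclohexyl in place of 3,5-dimethylbenzyl on an aromatic carbon. Going by the values given here, no measured step touches this aromatic carbon, so the data give no direct guide. Among the compounds with values here, the only step available moved nothing, so compound 3 is expected to lie near compound 1, with a 1.2-fold lower number from compound 1 to compound 3 (0.06 log units; within the scatter) not beyond the scatter. Compound 3 is therefore estimated at 20 10^-6 cm/s, expected between 8 10^-6 cm/s and 40 10^-6 cm/s.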

Compound 3, apparent permeability: 23 10^-6 cm/s
The estimate for compound 3 lay 1.2-fold (0.06 log units) below the measured number, and the stated range covers the measured number.
By their numbers in this assay, from the lowest: compounds 1, 2 and 3 (each within the scatter of the next).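

The aromatic carbon now has a measured step of its own in this assay: cyclohexyl in place of 3,5-dimethylbenzyl gives no change at the digits printed from compound 1 to compound 3 (within the scatter) on this read-out. The earlier compounds shown here varied only the group on the saturated chain carbon, whereas this step shows that a six-membered non-aromatic ring of 6 carbons and a group of 9 carbons holding an aromatic ring cannot be told apart here at this position. No available evidence accounts for this result.

Going by these compounds, both groups at this position are all-carbon and have no hydrogen-bond donors or acceptors, so it remains open whether an amine or a carboxylic acid there would read the same. On these data alone, it also remains open whether cyclohexyl would give the same reading alongside 5-fluoro-2-methoxyphenyl in place of furan-2-yl.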